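A Carbamate in Place of a Phenoxypropyl Ether

This account rests on a few compounds, and the source may have more. Where it says the series, first, only, none or still open, it means among the compounds named here.

Compound 1 `CC(C)=CCC1Cc2c(O)cc(=O)n(CCCO)c2CC1(C)C` carries a free hydroxyl on its aromatic ring, and in a functional assay on PANC-1 cells (Homo sapiens) for inhibition, read by MTT assay, with a stated time of 24 h, tested at 10 uM (a lower number here means less inhibition, a higher number more inhibition at the concentration tested (going by the name of the read-out)), compound 1 gives 0%. Compound 2 `CC(C)=CCC1Cc2c(OCCCOc3ccc(Cl)cc3)cc(=O)n(CCCO)c2CC1(C)C` bears a 3-(4-chlorophenoxy)propyl on that oxygen; in this assay compound 2 gives 0%. The only measured step is no change at the digits printed from compound 1 to compound 2 (within the scatter), so compound 2 stands level with compound 1 at the digits shown, and neither compound registers inhibition in this assay at the concentration tested.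

Compound 3 `CC(C)=CCC1Cc2c(OC(=O)Nc3cccc(F)c3)cc(=O)n(CCCO)c2CC1(C)C` differs from compound 2 in one place: (3-fluorophenyl)carbamoyl in place of 3-(4-chlorophenoxy)propyl on an oxygen on an aromatic ring. Among the compounds with values here, no measured step concerns a (3-fluorophenyl)carbamoyl, or any carbamate, on this oxygen. Within the data shown here, the one step that exists, no change at the digits printed from compound 1 to compound 2 (within the scatter), shows that replacing the hydrogen on this oxygen left this assay unmoved within the scatter, and the change from compound 2 to compound 3 again replaces a group on the same oxygen. The expectation is therefore a step of a number 5 percentage points higher from compound 2 to compound 3 (within the scatter) in this assay, nothing beyond the scatter. Compound 3 is estimated at 5% in this assay, with a range from 0% to 25%.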

Compound 3, a percentage reported as inhibition, at one concentration (the size of the read-out at that concentration, not a potency): 0%
Beside the measured number, compound 3's estimate is 5 percentage points above it; measured number inside the range.
By their numbers in this assay, from the lowest: compounds 1, 2 and 3 (each within the scatter of the next).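

On the oxygen on the aromatic ring, the earlier compounds had shown only that a 3-(4-chlorophenoxy)propyl ether left this assay unmoved. The result extends that observation to a different kind of substituent: there is no change at the digits printed from compound 2 to compound 3 (within the scatter), and there is also no change at the digits printed from compound 1 to compound 3 (within the scatter), so the free hydroxyl, the ether and the carbamate all stand level here, and neither the (3-fluorophenyl)carbamoyl group with its nitrogen nor the loss of the 3-(4-chlorophenoxy)propyl group separates these compounds at the concentration tested. No available evidence explains this flat result.

With all three compounds level, they give no read on whether any substituent on this oxygen can raise the inhibition, since no group here has yet moved the number away from the others. From the compounds shown here alone, it remains open how an amine or a carboxylic acid on this oxygen, a longer chain between the oxygen and the aromatic ring, or a replacement of the hydroxypropyl group on the shared core would read in this assay.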